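The source may report more compounds than this note shows. Statements on the series, on what has been measured and on what is new or still open speak of the compounds shown alone.

Compound 3 `COc1ccc(C(=O)N(C)c2ccc3[nH]c(-c4n[nH]c5ccccc45)cc3n2)cc1` gives 3320 nM in a functional assay on HL-60 cells (Homo sapiens) for antiproliferative activity, read by MTT assay, with a stated time of 72 h (on this read-out lower numbers stand for stronger inhibition and higher numbers for weaker inhibition), the second highest of the three numbers. Compound 2 `CN(C(=O)c1ccc(F)cc1)c1ccc2[nH]c(-c3n[nH]c4ccccc34)cc2n1` gives 1210 nM and compound 1 `CN(C(=O)C(C)(C)C)c1ccc2[nH]c(-c3n[nH]c4ccccc34)cc2n1` gives 4990 nM; the step of a 1.5-fold lower number from compound 1 to compound 3 (0.18 log units; within the scatter) stays within the scatter. Compound 4 `CN(c1ccc2[nH]c(-c3n[nH]c4ccccc34)cc2n1)S(=O)(=O)c1ccc(Cl)cc1` carries (4-chlorophenyl)sulfonyl in place of (4-methoxyphenyl)carbonyl on a nitrogen on an aromatic ring. Within the data shown here, no measured step exchanges a carbonyl for a sulfonyl, so that part of the change has no guide here. The halogen on the aromatic ring does have a precedent: a 2.7-fold higher number from compound 2 to compound 3 (0.44 log units; beyond the scatter), a modest step beyond the scatter, and a 4.1-fold lower number from compound 1 to compound 2 (0.62 log units; beyond the scatter). For compound 4 a modest lowering is therefore expected, a 1.8-fold lower number from compound 3 to compound 4 (0.27 log units; within the scatter), with wide uncertainty. The estimate for compound 4 in this assay is 1800 nM, between 600 nM and 5500 nM.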

Compound 4, half-maximal inhibitory concentration: 770 nM
Compound 4: middle estimate off by 2.3-fold (0.37 log units), on the high side; the measured number falls inside the stated range.
By their numbers in this assay, from the lowest: compounds 4 and 2 (each within the scatter of the next); then compounds 3 and 1 (each within the scatter of the next).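

In this assay, a sulfonyl group on this nitrogen gives a clear gain over two of the carbonyl groups, with a 4.3-fold lower number from compound 3 to compound 4 (0.63 log units; beyond the scatter) and a 6.5-fold lower number from compound 1 to compound 4 (0.81 log units; beyond the scatter), but a 1.6-fold lower number from compound 2 to compound 4 (0.20 log units; within the scatter) leaves it level with the (4-fluorophenyl)carbonyl group. The carbonyl is therefore not needed on this nitrogen to reach the lowest numbers seen so far. Nothing available explains these differences.

Going by these compounds, the sulfonyl and the chlorine enter together, so their separate contributions remain open. A (4-chlorophenyl)carbonyl group would separate them, while an amine on the aromatic ring remains an open question.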